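This account rests on a few compounds, and the source may have more. Where it says the series, first, only, none or still open, it means among the compounds named here.

Compound 1, `O=C(Nc1ccc(F)cc1)N1c2ccnn2CC1c1ccccc1`: 95 nM
Compound 2, `O=C(Nc1cccc2ccccc12)N1c2ccnn2CC1c1ccccc1`: > 1000 nM

In a functional assay on cells (Neutrophil, Homo sapiens) for inhibition, with a stated time of 10 min (on this read-out higher numbers stand for weaker inhibition and lower numbers for stronger inhibition), compound 1 gives 95 nM. For compound 2 this assay gives only > 1000 nM, which is a limit of the assay and not a measured number. That is where compound 2 stands among the two values shown: at a limit, with no exact figure, as summarised by the limit of > 1000 nM in this assay, at which 1 of the 2 values shown sits.

Compound 3, `NC(=O)c1cnn2c1N(C(=O)Nc1cccc3ccccc13)C(c1ccccc1)C2`, has not yet been measured in this assay. It differs from compound 2 in a single place: carbamoyl in place of hydrogen on an aromatic carbon. Going by the values given here, no pair of measured compounds shows what this change does, so there is nothing here to calibrate either its size or its direction. The step is expected to be a step that the limit leaves unreadable from compound 2 to compound 3, modest at most and uncertain in sign, since compound 2 itself only reached a limit. Compound 3 is estimated at 2000 nM, with a range from 300 nM to 10000 nM, and there is a fair chance that this assay will again report only a limit rather than a number.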

Compound 3, half-maximal inhibitory concentration: 110 nM
For compound 3 the middle estimate is 18-fold (1.26 log units) above the measured one; measured number outside the range, below it.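

In this assay, putting carbamoyl in place of hydrogen on an aromatic carbon gives an at least 9.0-fold lower number from compound 2 to compound 3 (0.95 log units; beyond the scatter). Going by these compounds alone, this is the first sign that this place, on the five-membered aromatic ring with 2 nitrogen, matters for the read-out, since compound 1 and compound 2 both carry hydrogen there and so could not reveal it. For compound 2 the reading is a limit and not a number, so the printed step sets only a minimum and its full size remains unknown: the limit of > 1000 nM in this assay, at which 1 of the 3 values shown sits.

Carbamoyl is the only group shown at this place, so a single step cannot tell whether the lower number needs the whole group or only part of it; a nitrile, a carboxylic acid or a simple methyl group on the same carbon would help to separate these possibilities. On these data alone, it also remains open whether the same change would lower the number for compound 1, which carries hydrogen at this place, as one step on a single pair of compounds says nothing about how the change behaves elsewhere.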